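The compounds below may be only part of what the source reports. "The series", "measured", "known", "first", "only" and "open" are said of these compounds alone.

Compound 1 `CC(=O)N1CCC[C@H](NS(C)(=O)=O)[C@@H]1CO[C@H]1CC[C@@H](C(C)C)CC1` is the reference point of this small set. Among the compounds with values here, in a functional assay on CHO-K1 cells for agonist activity at Orexin receptor type 2 (Homo sapiens), read by FLIPR and calcium flux (a higher number here means that more compound is needed for the effect, a lower number that less compound is needed), compound 1 gives 330 nM, the lowest of the two numbers known, while compound 2 `CC(=O)N1CCC[C@H](NS(=O)(=O)C(C)C)[C@@H]1CO[C@H]1CC[C@@H](C(C)C)CC1` gives 940 nM. Within the data shown here, the only measured step, a 2.8-fold higher number from compound 1 to compound 2 (0.45 log units; beyond the scatter), concerns the group on the sulfonyl sulfur and not the saturated six-membered ring. Compound 3 `CC(=O)N1CCC[C@H](NS(C)(=O)=O)[C@@H]1CO[C@H]1CC[C@@H](C)CC1` differs from compound 1 by methyl in place of isopropyl on a saturated ring carbon. Among the measured compounds shown here, no measured step touches this part of the structure, so the step from compound 1 to compound 2 serves only as a loose guide: it shows that enlarging one small group moved this assay beyond the scatter by a modest amount. Trimming the isopropyl to methyl on the ring is expected to shift the number upward by a comparable modest amount. Compound 3 is therefore estimated at 900 nM, with a range from 300 nM to 3000 nM. This expectation corresponds to a 2.7-fold higher number from compound 1 to compound 3 (0.44 log units; beyond the scatter).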

Compound 3, half-maximal effective concentration: 3700 nM
Compound 3: the middle estimate sits 4.1-fold (0.61 log units) below what was measured; the measured number lies above the stated range.
By their numbers in this assay, from the lowest: compound 1; then compound 2; then compound 3.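

Trimming isopropyl to methyl on this saturated ring carbon moves this assay much further than the change on the sulfonyl sulfur did: the step here is large (an 11-fold higher number from compound 1 to compound 3 (1.05 log units; beyond the scatter)), while the earlier one was modest (a 2.8-fold higher number from compound 1 to compound 2 (0.45 log units; beyond the scatter)). Of the two places varied, this one, three ring bonds from the ring atom that bears a large group, therefore shows the bigger change. The direction also differs, since isopropyl goes with the lower number on the ring but with the higher number on the sulfonyl sulfur, and nothing at hand accounts for either the size or the direction of these steps.

With only isopropyl and methyl shown on the ring, it remains open whether an ethyl group would fall between them or whether a tert-butyl group would lower the number further. From the compounds shown here alone, it is also open whether a hydroxyl group would be accepted at this ring carbon.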